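Cytotoxicity as the guanidine-type group shrinks to amino

A few compounds are considered here, and "the series" means these few. Any claim that something is new, unique, unknown or untested is made for them only; others in the source may bear on it.

Measured in an ADME assay on RD cells (Homo sapiens) for cytotoxicity, read by neutral red uptake, with a stated time of 3 days; on this read-out higher numbers stand for lower toxicity in this test and lower numbers for higher toxicity in this test:
Compound 1 `O=C(NC1CN2CCC1CC2)c1cc(-c2ccccc2)nc2ccccc12`: 46500 nM
Compound 2 `N=C(N)NC(=O)c1cc(-c2ccccc2)nc2ccccc12`: > 250000 nM

Compound 2 gives only a limit, > 250000 nM, and no number. Compound 3 `NNC(=O)c1cc(-c2ccccc2)nc2ccccc12` differs from it by one change: one nitrogen atom in place of a group of 3 heavy atoms (1 carbon, 2 nitrogen; no ring), on an amide-type nitrogen. Going by the values given here, only one measured step bears on this: an at least 5.3-fold higher number from compound 1 to compound 2 (0.73 log units; beyond the scatter). That step involved the same amide-type nitrogen, but the group it removed has rings and amino has none, so it guides only loosely. In this assay, no change beyond the scatter is expected, and the expected step is an at least 1.2-fold lower number from compound 2 to compound 3 (0.09 log units; that floor lies within the scatter). For compound 3 the estimated value is 200000 nM, with an expected range from 70000 nM to 350000 nM.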

Compound 3, half-maximal cytotoxic concentration: > 300000 nM
Compound 3: a limit, no number; the forecaster's own chance of this, stated with the estimate: 45%; middle value at least 1.5-fold (0.17 log units) away from the limit.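

In this assay compound 3 also ends in a limit and not a number: the limit of > 300000 nM in this assay, at which 1 of the 3 values shown sits. Amino on this amide-type nitrogen still gives an at least 6.4-fold higher number from compound 1 to compound 3 (0.80 log units; beyond the scatter), so a second small group without a ring stands clear of compound 1 in this test. The step from compound 2 to compound 3 cannot be read, with a limit on each side, so the two groups cannot be ordered.

From the compounds shown here alone, how far either compound lies past its limit stays open. So does whether a longer chain ending in an amine on this nitrogen would bring the number back towards that of compound 1.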